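The compounds below may be only part of what the source reports. "The series", "measured", "known", "first", "only" and "open" are said of these compounds alone.

Three compounds share one core and differ only in the aryl group on the amine nitrogen in a ring. Compound 1 `Nc1scc(CN2CCN(c3ccc(F)cc3Cl)CC2)c1C(=O)c1ccc(Cl)cc1` gives -6.2% in a functional assay on CHO cells with adenosine receptor A1 (Homo sapiens) as the target, read by cAMP accumulation and immunoassay, with a stated time of 6 min, tested at 0.1 uM; on this read-out lower numbers stand for a stronger effect and higher numbers for a weaker effect at the one concentration tested. Compound 2 `Nc1scc(CN2CCN(c3ccccc3C(F)(F)F)CC2)c1C(=O)c1ccc(Cl)cc1` gives -7.5% in this assay. Compound 3 `Nc1scc(CN2CCN(c3c(F)cccc3F)CC2)c1C(=O)c1ccc(Cl)cc1` gives -23%, the lowest of the three and so the strongest effect, since a number 16.8 percentage points lower from compound 1 to compound 3 (beyond the scatter) and a number 15.5 percentage points lower from compound 2 to compound 3 (beyond the scatter) both lie beyond the scatter. Compound 4 `Nc1scc(CN2CCN(c3c(F)cc(F)cc3F)CC2)c1C(=O)c1ccc(Cl)cc1` carries fluoro in place of hydrogen on an aromatic carbon, turning 2,6-difluorophenyl into 2,4,6-trifluorophenyl. Among the measured compounds shown here, no measured step adds a single fluoro to the aryl group; the two steps reaching compound 3 swapped whole aryl groups for modest shifts, while a number 1.3 percentage points lower from compound 1 to compound 2 (within the scatter) stayed within the scatter. A step within the scatter is therefore expected: a number 2 percentage points lower from compound 3 to compound 4 (within the scatter). Compound 4 is estimated at -25%, between -40% and -8%.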

Compound 4, a percentage reported as activity, at one concentration (the size of the read-out at that concentration, not a potency): -3.9%
Beside the measured number, compound 4's estimate is 21.1 percentage points below it, outside the stated range (above it).
By their numbers in this assay, from the lowest: compound 3; then compounds 2, 1 and 4 (each within the scatter of the next).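

Adding one fluoro on the aromatic carbon para to a large group, turning 2,6-difluorophenyl into 2,4,6-trifluorophenyl, matters in this assay: the change gives a number 19.1 percentage points higher from compound 3 to compound 4 (beyond the scatter) and the stronger effect of compound 3 does not carry over. Both a number 3.6 percentage points higher from compound 2 to compound 4 (within the scatter) and a number 2.3 percentage points higher from compound 1 to compound 4 (within the scatter) place compound 4 level with the compounds carrying other aryl groups. Nothing measured here explains this shift. Still open, going by these compounds, is whether a chloro, a methoxy or an amine on this same carbon would act like the hydrogen or like the fluoro.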